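A few compounds are considered here, and "the series" means these few. Any claim that something is new, unique, unknown or untested is made for them only; others in the source may bear on it.

Three nucleoside analogues that share a bicyclic core were tested in a functional assay on CEM-DNR-bulk cells (Homo sapiens), read by MTT assay, with a stated time of 72 h; a higher number here means a weaker inhibitor, a lower number a stronger inhibitor. Compound 1 `COc1nc(N)nc2c1c(-c1cccs1)cn2[C@@H]1O[C@H](CO)[C@@H](O)[C@H]1O` bears a thiophen-2-yl group, and in this assay compound 1 reaches only a limit, > 20000 nM. Compound 3 `COc1nc(N)nc2c1c(-c1ccoc1)cn2[C@@H]1O[C@H](CO)[C@@H](O)[C@H]1O` bears furan-3-yl in its place, and in this assay compound 3 likewise reaches only a limit, > 20000 nM. The step from compound 1 to compound 3 a step that the two limits leave unreadable from compound 1 to compound 3 arises from furan-3-yl in place of thiophen-2-yl on an aromatic carbon. Compound 2 `Nc1nc2c(c(-c3cccs3)cn2[C@@H]2O[C@H](CO)[C@@H](O)[C@H]2O)c(=O)[nH]1` has a different core; how its core differs from that of compound 1 is not broken down here. In this assay compound 2 also gives only a limit, > 20000 nM. Compound 4 `Nc1nc2c(c(-c3ccoc3)cn2[C@@H]2O[C@H](CO)[C@@H](O)[C@H]2O)c(=O)[nH]1` has not been measured and differs from compound 2 by furan-3-yl in place of thiophen-2-yl on an aromatic carbon, the same change as that from compound 1 to compound 3. Within the data shown here, all three measured values sit at the limit of > 20000 nM in this assay, at which 3 of the 3 values shown sit, so the one measured step has no readable size. Because of the limit of > 20000 nM in this assay, at which 3 of the 3 values shown sit, the step is expected to be a step that the limit leaves unreadable from compound 2 to compound 4. Compound 4 is therefore estimated at 30000 nM, between 10000 nM and 100000 nM.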

Compound 4, half-maximal inhibitory concentration: 15000 nM
Compound 4: the middle estimate sits 2.0-fold (0.30 log units) above what was measured; the measured number falls inside the stated range.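

In this assay, furan-3-yl in place of thiophen-2-yl on the core of compound 2 gives an at least 1.3-fold lower number from compound 2 to compound 4 (0.12 log units; that floor lies within the scatter). Going by these compounds, this shows that compound 4 gives a measured number where compound 2 reaches only a limit, but the floor of the step does not clear the usual scatter, so it shows no firm gain, and the true size of the step stays unknown. The same change on the core of compound 1 cannot be read, so the compounds do not show whether the step carries from one core to the other, and the two steps cannot be compared: the limit of > 20000 nM in this assay, at which 3 of the 4 values shown sit.

The compounds shown leave open whether furan-2-yl or thiophen-3-yl would separate the swap of sulfur for oxygen from the change in the point of attachment. They also leave open what a group of another kind at this aromatic carbon, such as a carboxylic acid or an amine, would give on either core.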